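A few compounds are considered here, and "the series" means these few. Any claim that something is new, unique, unknown or untested is made for them only; others in the source may bear on it.

Measured so far in an assay for inhibition of Amine oxidase [flavin-containing] B (Bos taurus), read by fluorescence, with a stated time of 60 min; a higher number here means a weaker inhibitor, a lower number a stronger inhibitor:
compound 1 `O=C(NNc1nc2ccccc2nc1Cc1ccccc1)c1ccc(Cl)cc1` gives 730000 nM
compound 2 `O=C(NNc1nc2ccccc2nc1Cc1ccccc1)c1ccc(O)cc1` gives 940000 nM

Compound 1 stands at the lowest of the two numbers in this assay; its nearest neighbour is compound 2, and the step from one to the other, a 1.3-fold higher number from compound 1 to compound 2 (0.11 log units; within the scatter), lies within the scatter, so the two values cannot be ordered.

Compound 3 `O=C(NNc1nc2ccccc2nc1Cc1ccccc1)c1ccc(Br)cc1` is the next member to be measured. Its difference from compound 1: bromo in place of chloro on an aromatic carbon. Going by the values given here, no measured step in this assay touches the same position with a halogen exchange; the only step on record, a 1.3-fold higher number from compound 1 to compound 2 (0.11 log units; within the scatter), swaps the chloro for a hydroxy at that position and stays within the scatter. That is the sole point of reference, and it gives no sign that this position moves the number much in either direction. The expectation for compound 3 is therefore a step of about a 1.0-fold lower number from compound 1 to compound 3 (0.02 log units; within the scatter), that is, no change beyond the scatter, with the range kept wide for lack of a direct precedent. Compound 3 is estimated at 700000 nM, between 330000 nM and 1500000 nM.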

Compound 3, half-maximal inhibitory concentration: 980000 nM
The estimate for compound 3 lay 1.4-fold (0.15 log units) below the measured number; measured number inside the range.
By their numbers in this assay, from the lowest: compounds 1, 2 and 3 (each within the scatter of the next).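

Working notes on the para position of the 4-halophenyl carbonyl part. In this assay, a direct halogen exchange can now be read: bromo in place of chloro gives (a 1.3-fold higher number from compound 1 to compound 3 (0.13 log units; within the scatter)), so the assay does not separate these two halogens on this aromatic carbon, para to a large group. Going by these compounds alone, the new comparison with the hydroxy member, bromo in place of hydroxy, gives (a 1.0-fold higher number from compound 2 to compound 3 (0.02 log units; within the scatter)), which means that chloro, hydroxy and bromo now all lie within the scatter of one another, where previously only one pair of groups could be compared at this position. No evidence on hand offers an explanation for these three values.

Going by these compounds, it remains open whether any group at this position can shift the number beyond the scatter, for example an amine, a carboxylic acid or a longer chain such as butoxy in place of the halogen. The compounds shown also leave open whether a change elsewhere on the shared core, such as replacing the benzyl group, would have any larger effect in this assay.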